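Dropping the Acetoxy Group from a Brominated Furanone

A few compounds are considered here, and "the series" means these few. Any claim that something is new, unique, unknown or untested is made for them only; others in the source may bear on it.

Compound 1 `CCC[C@@H](OC(C)=O)C1=C(Br)/C(=C/Br)OC1=O`: 1 ug/mL
Compound 2 `CCC[C@@H](OC(C)=O)C1=C(Br)[C@@](C)(OC)OC1=O`: 2.8 ug/mL

In a functional assay on KB cells (Homo sapiens) for cytotoxicity (a higher number here means that more compound is needed for the effect, a lower number that less compound is needed), compound 1 gives 1 ug/mL, the lowest of the two numbers. Compound 2 gives 2.8 ug/mL, a higher number that lies beyond the usual scatter. Compound 3 `CCCCC1=C(Br)/C(=C/Br)OC1=O` has not yet been measured. It differs from compound 1 by hydrogen in place of acetoxy on a saturated chain carbon bound to a double-bonded ring carbon and a saturated chain carbon. Going by the values given here, no measured pair shows this change, so there is no direct guide; a modest rise in the number in this assay is expected, a step of a 2.5-fold higher number from compound 1 to compound 3 (0.40 log units; beyond the scatter). Compound 3 is therefore estimated at 2.5 ug/mL, with a range from 0.8 ug/mL to 8 ug/mL.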

Compound 3, concentration for half-maximal effect: > 20 ug/mL
Compound 3: no number, only a limit (the forecaster's own chance of this, stated with the estimate: 5%); middle value at least 8.0-fold (0.90 log units) away from the limit.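

Putting hydrogen in place of acetoxy on this saturated chain carbon gives an at least 20-fold higher number from compound 1 to compound 3 (1.30 log units; beyond the scatter) in this assay, so the group at this place weighs heavily in this assay. Compound 3 gives > 20 ug/mL, which is a limit of the assay and not a number. The full size of the step stays unknown because the reading ends at a limit: the limit of > 20 ug/mL in this assay, at which 1 of the 3 values shown sits.

The compounds shown do not tell which part of the acetoxy group counts. A hydroxyl or a benzoyloxy group on this carbon would address that question.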